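Lengthening the ether chain: notes on compounds 1 to 4

The source may report more compounds than this note shows. Statements on the series, on what has been measured and on what is new or still open speak of the compounds shown alone.

Measured so far in a functional assay on MES-SA cells (Homo sapiens) for inhibition, with a stated time of 72 h, in the presence of a further agent that is not named here; a lower number here means a stronger inhibitor, a higher number a weaker inhibitor:
compound 1, `COCc1cc(CN2CCCC2)c(O)c2ncccc12`, 10500 nM
compound 2, `CCOCc1cc(CN2CCCC2)c(O)c2ncccc12`, 8710 nM
compound 3, `CCOCc1cc(CN2CCCCC2)c(O)c2ncccc12`, 9120 nM

All three measured compounds sit close together. From compound 1 to compound 2 the change is methyl in place of hydrogen on a saturated chain carbon bound to an oxygen on a saturated carbon and the step in this assay is a 1.2-fold lower number from compound 1 to compound 2 (0.08 log units; within the scatter). From compound 2 to compound 3 the change is piperidin-1-yl in place of pyrrolidin-1-yl on a saturated chain carbon bound to an aromatic carbon, with a step of a 1.0-fold higher number from compound 2 to compound 3 (0.02 log units; within the scatter). Compound 1 and compound 3 differ in more than one place; the difference between the two cores is not broken down here, and their two values lie within the scatter of each other.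

Compound 4, `CCCOCc1cc(CN2CCCCC2)c(O)c2ncccc12`, has not yet been measured. It differs from compound 3 by methyl in place of hydrogen on a saturated chain carbon, two bonds along the chain from an oxygen on a saturated carbon. Among the compounds with values here, this is the same kind of change as the one from compound 1 to compound 2, but the place is not the same: in compound 1 the carbon that gains the methyl is bound to an oxygen on a saturated carbon, whereas in compound 3 it is two bonds along the chain from an oxygen on a saturated carbon. The earlier occurrence of this kind of change gave a 1.2-fold lower number from compound 1 to compound 2 (0.08 log units; within the scatter), which is within the scatter, and the expectation for compound 4 rests on that single precedent. The step from compound 3 to compound 4 in this assay is therefore expected to be a 1.1-fold lower number from compound 3 to compound 4 (0.03 log units; within the scatter). Compound 4 is estimated at 8500 nM, with a likely range from 4500 nM to 16000 nM.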

Compound 4, half-maximal inhibitory concentration: 3550 nM
Compound 4: middle estimate off by 2.4-fold (0.38 log units), on the high side; the whole stated range lies above it.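

In this assay, the methyl that turns ethoxy into propoxy gives a 2.6-fold lower number from compound 3 to compound 4 (0.41 log units; beyond the scatter), and this is the only step among the compounds shown that lies beyond the scatter. Set beside the earlier case of the same kind of change, on the other core and at a different place on the chain, the new step cannot be told apart from it: the same change on two cores in this assay, a 1.2-fold lower number (0.08 log units; within the scatter) from compound 1 to compound 2 and a 2.6-fold lower number (0.41 log units; beyond the scatter) from compound 3 to compound 4, 2.1-fold (0.33 log units) apart, within the scatter of two such steps. Within the data shown here, this shows that carrying the change from one core to the other gives no measurable difference between the two steps, but it does not show that they are equal, that the core has no influence, or that each added methyl gives a real gain, since the step from compound 1 to compound 2 alone stays within the scatter and only one pair stands on each core.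

Going by these compounds, it remains open whether propoxy gives a step of this size with pyrrolidin-1-yl in place of piperidin-1-yl, which would separate the effect of the core from that of the place on the chain. On these data alone, it also remains open whether the trend continues to a longer chain such as butoxy, or holds for a branched ether such as isopropoxy.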